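The compounds below may be only part of what the source reports. "The series", "measured", "known", "first", "only" and "open" are said of these compounds alone.

Of the compounds shown here, two from this series have been measured in an assay on isolated protein for inhibition of Rho-associated protein kinase 1 (Homo sapiens), read by scintillation counting, radiometric assay and 33P incorporation, with a stated time of 40 min, in the presence of a further agent that is not named here; a lower number here means a stronger inhibitor, a higher number a weaker inhibitor. Compound 1, `O=C(COc1ccc2c(=O)ccoc2c1)Nc1cccc(NC(=O)c2ccc(Br)cc2)c1`, gives 303 nM in this assay. Compound 2, `Nc1ccc(C(=O)Nc2cccc(NC(=O)COc3ccc4c(=O)ccoc4c3)c2)cc1`, gives 802 nM in this assay. The only difference between them is a single group on the outer benzene ring, and the step of a 2.6-fold higher number from compound 1 to compound 2 (0.42 log units; beyond the scatter) shows that this exchange weakened inhibition. Compound 2 therefore holds the higher of the two numbers, with compound 1 as its nearest neighbour.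

Compound 3, `O=C(COc1ccc2c(=O)ccoc2c1)Nc1cccc(NC(=O)c2ccc(C(=O)O)cc2)c1`, is the next compound in the series and has not yet been measured. It differs from compound 2 by carboxy in place of amino on an aromatic carbon. Within the data shown here, no measured step covers this exchange directly; the only step that bears on it, a 2.6-fold higher number from compound 1 to compound 2 (0.42 log units; beyond the scatter), concerns the same position and was modest in size. On that basis a change in this assay of similar scale, in either direction, is expected, with a slight lean towards a higher number, which is what the estimate a 1.5-fold higher number from compound 2 to compound 3 (0.18 log units; within the scatter) expresses. Compound 3 is estimated at 1200 nM in this assay, within a range from 400 nM to 4000 nM.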

Compound 3, half-maximal inhibitory concentration: 6890 nM
Compound 3: middle estimate off by 5.7-fold (0.76 log units), on the low side; the whole stated range lies below it.
By their numbers in this assay, from the lowest: compound 1; then compound 2; then compound 3.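

The position para to a large group turns out to be far more sensitive than the first pair suggested: in this assay, the change to carboxy gives an 8.6-fold higher number from compound 2 to compound 3 (0.93 log units; beyond the scatter) and, measured against the bromo compound, a 23-fold higher number from compound 1 to compound 3 (1.36 log units; beyond the scatter). The three compounds now form an order, with compound 1 the strongest inhibitor and compound 3 the weakest, and each step between neighbours lies beyond the scatter, so the group at this one position can by itself move the result over a wide range. Amino and carboxy have the same counted hydrogen-bond donors and acceptors, so those counts do not separate them, and nothing available here explains the loss.

The compounds shown leave open whether the loss belongs to the free carboxylic acid itself or would persist with its methyl ester or a primary amide at the same position. They also leave open how a chloro, methyl or methoxy group would rank against bromo, and so whether any group here can give a lower number than compound 1.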